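The compounds below may be only part of what the source reports. "The series", "measured", "known", "first", "only" and "open" are said of these compounds alone.

Working notes on the series. Three measured analogues share one core and differ only in the group carried on the pendant phenyl ring. Compound 1 `CN(C)c1ccc(-c2nc3c(=O)n(C)c(=O)n(C)c3[nH]2)cc1` gives 1.8 nM in an assay for binding affinity to adenosine receptor A1 (Bos taurus); a higher number here means a weaker inhibitor, a lower number a stronger inhibitor. Compound 2 `CCc1ccc(-c2nc3c(=O)n(C)c(=O)n(C)c3[nH]2)cc1` gives 0.8 nM in this assay, and compound 3 `Cn1c(=O)c2nc(-c3ccc(Br)cc3)[nH]c2n(C)c1=O` gives 0.75 nM. Compound 3 carries the lowest number of the three, but the comparison is uneven: against compound 2 it shows a 1.1-fold lower number from compound 2 to compound 3 (0.03 log units; within the scatter), whereas against compound 1 it shows a 2.4-fold lower number from compound 1 to compound 3 (0.38 log units; beyond the scatter). The remaining pair shows a 2.3-fold lower number from compound 1 to compound 2 (0.35 log units; beyond the scatter).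

The next step is compound 4 `Cn1c(=O)c2nc(-c3ccc([N+](=O)[O-])cc3)[nH]c2n(C)c1=O`, in which (nitro in place of bromo on an aromatic carbon). Within the data shown here, no measured step exchanges the bromo for a nitro, so the bearing steps are the two that placed or removed a group at the same position: the bromo-for-ethyl swap was within the scatter, and the bromo-for-dimethylamino swap was modest. Across all three measured compounds the spread at this position stays modest, so no large movement is expected here; the expected step is a 2.0-fold higher number from compound 3 to compound 4 (0.30 log units; within the scatter), a slightly higher number in this assay, of a size within or barely beyond the scatter. Compound 4 is estimated at 1.5 nM, with a range from 0.5 nM to 5 nM.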

Compound 4, half-maximal inhibitory concentration: 8 nM
Estimate against measurement, compound 4: 5.3-fold (0.73 log units) below; the measured number lies above the stated range.
By their numbers in this assay, from the lowest: compounds 3 and 2 (each within the scatter of the next); then compound 1; then compound 4.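

The position on the pendant phenyl ring, para to a large group, is more sensitive than the three earlier compounds suggested: in this assay, nitro in place of bromo gives an 11-fold higher number from compound 3 to compound 4 (1.03 log units; beyond the scatter), while nitro in place of ethyl gives a 10-fold higher number from compound 2 to compound 4 (1.00 log units; beyond the scatter). Even against compound 1, the highest number among the earlier compounds, nitro in place of dimethylamino gives a 4.4-fold higher number from compound 1 to compound 4 (0.65 log units; beyond the scatter), so the exchanges among bromo, ethyl and dimethylamino all remained smaller than any step to nitro. The nitro group differs from bromo by bringing three heavy atoms in place of one and two hydrogen-bond acceptors in place of none, but no measurement shown links either difference or any other feature of the nitro group to the higher number.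

On these data alone, whether this higher number is peculiar to nitro or is shared by other groups at this position, such as a nitrile, a carboxylic acid or a primary amine, remains open. Also open, as far as these compounds go, is whether a methoxy or a chloro group would stay with bromo and ethyl or move towards nitro.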